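Sulfonamide-amine series: aryl swap on the sulfonyl sulfur

This account rests on a few compounds, and the source may have more. Where it says the series, first, only, none or still open, it means among the compounds named here.

Measured so far in a functional assay on MIA PaCa-2 cells (Homo sapiens) for inhibition, read by MTT assay, with a stated time of 72 h; a lower number here means a stronger inhibitor of growth, a higher number a weaker inhibitor of growth:
- compound 1, `Cc1ccc(C)c(S(=O)(=O)NCCCCCCNCc2ccc(Br)cc2)c1`: 12000 nM
- compound 2, `O=S(=O)(NCCCNCc1ccc(Cl)cc1)c1cc(C(F)(F)F)cc(C(F)(F)F)c1`: 2800 nM
- compound 3, `O=S(=O)(NCCCNCc1cccc(Cl)c1)c1cc(C(F)(F)F)cc(C(F)(F)F)c1`: 4400 nM

Compound 1 stands highest of the three numbers in this assay. Its nearest neighbour is compound 3, whose value is lower, and furthest is compound 2, whose value is lower still; both gaps lie beyond the scatter. Going by the values given here, the one step measured, a 1.6-fold higher number from compound 2 to compound 3 (0.20 log units; within the scatter), moves the chlorine on the benzyl ring and stays within the scatter.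

Compound 4, `O=S(=O)(NCCCCCCNCc1ccc(Br)cc1)c1c(Cl)cccc1Cl`, is not yet measured. It differs from compound 1 in one place: 2,6-dichlorophenyl in place of 2,5-dimethylphenyl on a sulfonyl sulfur. Among the compounds with values here, no measured step touches the aryl group on the sulfonyl sulfur; compounds 2 and 3 carry a different aryl group there but also differ from compound 1 elsewhere, so their lower values cannot be separated into a contribution from that group alone. Within the data shown here, the only measured step, on the benzyl ring, is within the scatter and bears on the change to compound 4 not at all.

Among the measured compounds shown here, with no direct precedent, compound 4 is expected to sit near compound 1, with a weak lean towards a lower number, a 1.5-fold lower number from compound 1 to compound 4 (0.18 log units; within the scatter), well within a wide band. The estimate for compound 4 in this assay is 8000 nM, between 2500 nM and 25000 nM.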

Compound 4, concentration for 50% growth inhibition: 14700 nM
Beside the measured number, compound 4's estimate is 1.8-fold (0.26 log units) below it, within the range that was stated.
By their numbers in this assay, from the lowest: compounds 2 and 3 (each within the scatter of the next); then compounds 1 and 4 (each within the scatter of the next).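

Going by these compounds alone, replacing 2,5-dimethylphenyl with 2,6-dichlorophenyl on a sulfonyl sulfur gives a 1.2-fold higher number from compound 1 to compound 4 (0.09 log units; within the scatter) in this assay and is the first step to isolate the aryl group at this position, since the shared hexyl-linked core and 4-bromobenzyl group stay fixed. On this core, the two aryl groups, each with 8 heavy atoms and one six-membered aromatic ring of carbon only, cannot be told apart in this read-out, so this particular swap leaves growth inhibition unresolved from the scatter and the position tolerates it. No measurement on hand accounts for the two groups reading alike.

Within the data shown here, the step covers only this one pair of aryl groups on this one core, so it cannot show whether the trifluoromethyl-bearing aryl group of compounds 2 and 3 would read differently on the core of compound 1, or whether the chain or the benzyl ring sets the values of those compounds. Also open, as far as these compounds go, is how this position responds to an aryl group carrying something quite different, such as a carboxylic acid or an amine.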